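A few compounds are considered here, and "the series" means these few. Any claim that something is new, unique, unknown or untested is made for them only; others in the source may bear on it.

Among the compounds with values here, in a physicochemical assay for solubility, measured as kinetic solubility (a lower number here means a less soluble compound, a higher number a more soluble compound), compound 1 `CCC/N=C1\S/C(=C\c2ccc(O)c(Cl)c2)C(=O)N1C1CCOCC1` gives 70000 nM and compound 2 `CCC/N=C1\S/C(=C\c2ccc(O)c(Cl)c2)C(=O)N1C(C)C` gives 20000 nM, so compound 2 holds the lower of the two numbers so far. The next structure is compound 3 `CCC/N=C1\S/C(=C\c2ccc(O)c(Cl)c2)C(=O)N1c1ccccc1O`, and the change is 2-hydroxyphenyl in place of isopropyl on an amide-type nitrogen in a ring. Within the data shown here, only one measured step bears on this position: a 3.5-fold lower number from compound 1 to compound 2 (0.54 log units; beyond the scatter), modest but beyond the scatter, with isopropyl in place of oxan-4-yl. It shows that the number moves with the group at this nitrogen, but no aromatic group has been measured there, so the basis is thin. A modest further move to a lower number in this assay is expected, though the direction is uncertain. The estimate for compound 3 is 10000 nM, with a range of 3000 nM to 30000 nM. The expected change is a 2.0-fold lower number from compound 2 to compound 3 (0.30 log units; within the scatter).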

Compound 3, solubility: 220000 nM
Estimate against measurement, compound 3: 22-fold (1.34 log units) below; measured number above the stated range.
By their numbers in this assay, from the lowest: compound 2; then compound 1; then compound 3.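

In this assay the group on the amide-type nitrogen in a ring controls a wider span than the first pair suggested: 2-hydroxyphenyl in place of isopropyl gives an 11-fold higher number from compound 2 to compound 3 (1.04 log units; beyond the scatter) and is a large step. Against oxan-4-yl, the same group gives a 3.1-fold higher number from compound 1 to compound 3 (0.50 log units; beyond the scatter) and is a modest step. An aromatic ring at this nitrogen therefore does not go with a lower number here, since compound 3 stands highest of the three, with both of its steps beyond the scatter.

The compounds shown leave open whether these steps belong to the aromatic ring or to its hydroxyl, a question that an unsubstituted phenyl or a 2-methoxyphenyl at this nitrogen would address. No supporting measurement is available to account for the result.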